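The compounds below may be only part of what the source reports. "The series", "measured", "known", "first", "only" and "open" are said of these compounds alone.

Going by the values given here, the three compounds measured so far share one core. Compound 1 `Cc1cc(=O)oc2cc(Sc3cccc(Cl)[n+]3[O-])ccc12` gives 24500 nM in a functional assay on KBVIN cells (Homo sapiens) for antiproliferative activity, read by sulforhodamine B assay, with a stated time of 72 h (on this read-out higher numbers stand for weaker inhibition of growth and lower numbers for stronger inhibition of growth), and compound 2 `Cc1cc(=O)oc2cc(Sc3cccc(Cl)n3)ccc12` gives 920 nM in this assay. Compound 3 `Cc1cc(=O)oc2cc(SCc3ccccn3)ccc12` stands at the limit of > 35200 nM in this assay, at which 1 of the 3 values shown sits, which is a limit of the assay and not a number, so its entry of > 35200 nM tells only where measurement stopped. Compound 4 `Cc1cc(=O)oc2cc(SCc3ccncc3)ccc12` differs from compound 3 by pyridin-4-yl in place of pyridin-2-yl on a saturated chain carbon bound to a sulfur. Among the compounds with values here, no measured pair isolates this kind of change, so the data give no direct size for it. Since compound 3 already sits at the limit, the step that the limit leaves unreadable from compound 3 to compound 4 is expected to be none beyond the scatter, with compound 4 expected to remain at or near the limit. For compound 4 the estimate is 40000 nM, with a range from 15000 nM to 100000 nM.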

Compound 4, concentration for 50% growth inhibition: > 35200 nM
Compound 4: a limit, no number; the forecaster's own chance of this, stated with the estimate: 70%; the middle value does not contradict the limit.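

No step can be read from compound 3 to compound 4, since both entries in this assay are limits and not numbers: the limit of > 35200 nM in this assay, at which 2 of the 4 values shown sit. The compounds shown leave open whether pyridin-4-yl in place of pyridin-2-yl on a saturated chain carbon bound to a sulfur alters growth inhibition at all.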